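A few compounds are considered here, and "the series" means these few. Any claim that something is new, unique, unknown or untested is made for them only; others in the source may bear on it.

In an assay on CHO cells, read by calcium flux (a lower number here means a stronger inhibitor, a higher number a weaker inhibitor), compound 3 `O=C(Nc1ccc(C(F)(F)F)cc1)c1csc(Nc2c(Cl)cccc2Cl)n1` gives 51 nM, the lowest of the two numbers reported. Compound 1 `O=C(Nc1ccc(C(F)(F)F)cc1)c1csc(Cc2c(Cl)cccc2Cl)n1` gives 140 nM in this assay, and the step is a 2.7-fold lower number from compound 1 to compound 3 (0.44 log units; beyond the scatter). Compound 2 `O=C(Nc1ccc(C(F)(F)F)cc1)c1csc(-c2c(Cl)cccc2Cl)n1` reaches only a limit of this assay, > 4000 nM. From there, an at least 78-fold lower number from compound 2 to compound 3 (1.89 log units; beyond the scatter), and an at least 28-fold higher number from compound 1 to compound 2 (1.45 log units; beyond the scatter). Compound 4 `NS(=O)(=O)c1cc(Cl)c(Nc2nc(C(=O)Nc3ccc(C(F)(F)F)cc3)cs2)c(Cl)c1` differs from compound 3 by sulfamoyl in place of hydrogen on an aromatic carbon. Among the measured compounds shown here, all three measured steps alter the link between the shared core and the 2,6-dichlorophenyl ring; none changes a substituent on that ring, so no measured step bears directly on this change. The step of a 1.2-fold higher number from compound 3 to compound 4 (0.07 log units; within the scatter) is therefore expected to stay within or near the scatter, and compound 4 is estimated at 60 nM, between 20 nM and 250 nM.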

Compound 4, half-maximal inhibitory concentration: 1780 nM
Compound 4: the middle estimate sits 30-fold (1.47 log units) below what was measured; the measured number lies above the stated range.
By their numbers in this assay, from the lowest: compound 3; then compound 1; then compound 4. At a limit, above all of these: compound 2.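

The earlier steps shown here changed only the link between the shared core and the 2,6-dichlorophenyl ring, whereas compound 4 carries a change on that ring itself. In this assay, sulfamoyl in place of hydrogen, meta to two chloro groups, gives a 35-fold higher number from compound 3 to compound 4 (1.54 log units; beyond the scatter) and so shows that this position does not tolerate every group. Nothing among the data shown accounts for this rise. As far as these compounds go, whether any group here raises the number, or sulfamoyl in particular, stays open. A methyl group, an amine or a carboxylic acid at this position would help separate the two.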